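The compounds below may be only part of what the source reports. "The series", "measured", "known", "first", "only" and "open" are said of these compounds alone.

Compound 1 `N[C@H]1CC[C@H](Nc2c(C(=O)NCc3ccc(Cl)cc3)nc(Br)c3cccnc23)CC1` is the anchor here. For the measured compounds named here, in a functional assay on HEY cells (Homo sapiens) for cytotoxicity, read by MTT assay, with a stated time of 72 h (a lower number here means a stronger inhibitor, a higher number a weaker inhibitor), compound 1 gives 1000 nM, the only single number among the three values shown. Compound 2 `COC(=O)c1nc(Br)c2cccnc2c1N[C@H]1CC[C@H](N)CC1` reaches only a limit of this assay, > 20000 nM. For compound 3 `N[C@H]1CC[C@H](Nc2c(C(=O)NCc3ccc(F)cc3)nc(Br)c3cccnc23)CC1` the outcome in this assay is recorded as "not determined" (no result reported). Going by the values given here, the one measured step, an at least 20-fold higher number from compound 1 to compound 2 (1.30 log units; beyond the scatter), replaces the whole (4-chlorobenzyl)amino group on the carbonyl carbon, so it does not speak directly to a change on the aromatic ring alone. Compound 4 `N[C@H]1CC[C@H](Nc2c(C(=O)NCc3ccccc3)nc(Br)c3cccnc23)CC1` differs from compound 1 by hydrogen in place of chloro on an aromatic carbon. Among the compounds with values here, no measured step removes a chloro, so I expect a step of a 1.5-fold higher number from compound 1 to compound 4 (0.18 log units; within the scatter) within the scatter. My estimate for compound 4 is 1500 nM, between 500 nM and 5000 nM.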

Compound 4, half-maximal inhibitory concentration: 8000 nM
Estimate against measurement, compound 4: 5.3-fold (0.73 log units) below; the measured number lies above the stated range.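

In this assay, the chloro on the ring clearly counts: putting hydrogen in its place gives an 8.0-fold higher number from compound 1 to compound 4 (0.90 log units; beyond the scatter). Even without the chloro, benzylamino in place of methoxy on the carbonyl carbon still gives an at least 2.5-fold lower number from compound 2 to compound 4 (0.39 log units; beyond the scatter), so the amide side chain matters with or without that atom. That step rests on the value of compound 2, which is a limit and not a number: the limit of > 20000 nM in this assay, at which 1 of the 4 values shown sits.

From the compounds shown here alone, whether chloro itself is special remains open, since a methyl or a trifluoromethyl at the same ring carbon could do as well or better.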